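Methylsulfanyl on the Biphenyl Amide of a Boronic Series

This account rests on a few compounds, and the source may have more. Where it says the series, first, only, none or still open, it means among the compounds named here.

Compound 1, `O=C(CCc1cccc2c1B(O)OC2)Nc1ccc([N+](=O)[O-])cc1`, was examined in an ADME assay on WI-38 cells (Homo sapiens) for cytotoxicity, read by MTT assay, with a stated time of 72 h; a higher number here means a weaker inhibitor, a lower number a stronger inhibitor. In this assay compound 1 reports only a limit, > 100000 nM, and no number. Compound 2, `O=C(CCc1cccc2c1B(O)OC2)Nc1cccc(-c2ccccc2)c1`, carries a phenyl on the anilide ring in place of the nitro group, and in this assay compound 2 gives 12000 nM. Among the values shown, compound 2 thus stands alone as the one with a number; the remaining entry is the limit of > 100000 nM in this assay, at which 1 of the 2 values shown sits. Compound 3, `CSc1ccc(-c2cccc(NC(=O)CCc3cccc4c3B(O)OC4)c2)cc1`, has not yet been measured in this assay. It differs from compound 2 by methylsulfanyl in place of hydrogen on an aromatic carbon. Going by the values given here, no step between two measured compounds is available, so the effect of this change cannot be read from earlier pairs. The step of a 1.5-fold lower number from compound 2 to compound 3 (0.18 log units; within the scatter) is expected to be small, within the usual scatter or at most a modest move toward a stronger inhibitor. Compound 3 is therefore estimated at 8000 nM, with a likely range from 3000 nM to 25000 nM.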

Compound 3, half-maximal inhibitory concentration: 3800 nM
For compound 3 the middle estimate is 2.1-fold (0.32 log units) above the measured one; the measured number falls inside the stated range.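

The methylsulfanyl group on the outer phenyl gives the series its first readable step in this assay, with a 3.2-fold lower number from compound 2 to compound 3 (0.50 log units; beyond the scatter) for this single change. It shows that this place, para to a large group, responds to substitution: phenyl to 4-(methylsulfanyl)phenyl moves the number toward a stronger inhibitor, modestly but beyond the scatter. Going by these compounds alone, compound 1 still gives only a limit and not a number, so it adds no second step: the limit of > 100000 nM in this assay, at which 1 of the 3 values shown sits.

Going by these compounds, whether this step belongs to the sulfur itself remains open, and so does what a methoxy group, a chlorine atom or an amine would do at the same place. Also open, on these data alone, is whether a longer chain such as ethylsulfanyl would carry the move further or reverse it.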